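From compound 1 to compound 4: cytotoxicity notes

The source may report more compounds than this note shows. Statements on the series, on what has been measured and on what is new or still open speak of the compounds shown alone.

Measured in an ADME assay on ECV-304 cells (Homo sapiens) for cytotoxicity, read by MTT assay, with a stated time of 72 h; a higher number here means a weaker inhibitor, a lower number a stronger inhibitor:
- compound 1 `COc1ccc(C2=C(c3cc(OC)c(OC)c(OC)c3)C(=O)CC2O[SiH2]C(C)(C)C)cc1`: > 100 ug/mL, a limit
- compound 2 `COc1ccc(C2=C(c3cc(OC)c(OC)c(OC)c3)C(=O)C(O)C2)cc1F`: 19.5 ug/mL
- compound 3 `COc1ccc(C2=C(c3cc(OC)c(OC)c(OC)c3)C(=O)CC2O)cc1`: > 100 ug/mL, a limit

Compound 1 stands at the limit of > 100 ug/mL in this assay, at which 2 of the 3 values shown sit, so it offers a limit and no number. The structure to be tested next is compound 4 `COc1cc(C2=C(c3cc(C)c(OC)c(C)c3)C(O[SiH2]C(C)(C)C)CC2=O)cc(OC)c1OC`. The change is 4-methoxy-3,5-dimethylphenyl in place of 4-methoxyphenyl on a double-bonded ring carbon.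

For the measured compounds named here, no measured step covers this change. Going by the values given here, the one available step, a step that the two limits leave unreadable from compound 1 to compound 3, concerns a group on an oxygen on a saturated carbon and gives no size. Among the compounds with values here, compound 2 is the only compound with a number, and no measured step connects it to this change.

With no measured size to carry over, no step beyond the scatter is expected in this assay, and none is expected in either direction. Compound 4 may well report only a limit again. The estimated step is a step that the limit leaves unreadable from compound 1 to compound 4. Compound 4 is estimated at 110 ug/mL, with an expected range of 40 ug/mL to 300 ug/mL.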

Compound 4, half-maximal inhibitory concentration: 15 ug/mL
For compound 4 the middle estimate is 7.3-fold (0.87 log units) above the measured one; the measured number lies below the stated range.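

In this assay, 4-methoxy-3,5-dimethylphenyl in place of 4-methoxyphenyl on a double-bonded ring carbon gives an at least 6.6-fold lower number from compound 1 to compound 4 (0.82 log units; beyond the scatter), the only step with a readable size among the compounds shown. This position therefore responds to a change of aryl group, which the earlier change on the oxygen could not show, and compound 4 gives a number, 15 ug/mL, where its partner offers none. The size is only a bound, since the compound 1 end of the step is a limit: the limit of > 100 ug/mL in this assay, at which 2 of the 4 values shown sit.

The compounds shown leave open whether one methyl group alone would carry this step, and whether an amine or a longer chain in place of the methyl groups of 4-methoxy-3,5-dimethylphenyl would read the same way. Also open, from the compounds shown here alone, is whether the same aryl change would give a step on the core of compound 3.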